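This account rests on a few compounds, and the source may have more. Where it says the series, first, only, none or still open, it means among the compounds named here.

In a functional assay on CHO cells for agonist activity at transient receptor potential cation channel subfamily V member 1 (Homo sapiens) (a higher number here means that more compound is needed for the effect, a lower number that less compound is needed), compound 1 `CC(C)(C)c1ccc(-c2cccc(Nc3ccc4c(c3)OCCO4)n2)cc1` gives only a limit, > 4000 nM. Compound 2 `CC(C)(C)c1ccc(-c2cc(Nc3ccc4c(c3)OCCO4)ncn2)cc1` likewise gives only a limit in this assay, > 4000 nM. Going by the values given here, both results sit at the limit of > 4000 nM in this assay, at which 2 of the 2 values shown sit, so no step between measured compounds can be sized here, and compound 2 stands at that limit with no firm number. Compound 3 `FC(F)(F)c1ccc(-c2cc(Nc3ccc4c(c3)OCCO4)ncn2)cc1` differs from compound 2 in one place: trifluoromethyl in place of tert-butyl on an aromatic carbon. The step in this assay is expected to be a step that the limit leaves unreadable from compound 2 to compound 3, none beyond the scatter, with a limit again the most likely outcome. Compound 3 is estimated at 8000 nM, within a range from 3000 nM to 25000 nM.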

Compound 3, half-maximal effective concentration: > 4000 nM
Compound 3: no number, only a limit; the forecaster's own chance of this, stated with the estimate: 80%; the middle value is on the limit's open side.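

Compound 3, like compound 2, gives only a limit and no firm number, so no step between the two can be read: the limit of > 4000 nM in this assay, at which 3 of the 3 values shown sit.

The compounds shown leave open how much of each is needed for the effect in this assay, and whether trifluoromethyl in place of tert-butyl changes that amount.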